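Replacing an Amino Group with a Selenium-Bearing Group

A few compounds are considered here, and "the series" means these few. Any claim that something is new, unique, unknown or untested is made for them only; others in the source may bear on it.

Of the compounds shown here, two sharing one core have been measured so far. In a functional assay on A549 cells (Homo sapiens) for antiproliferative activity, read by MTT assay, with a stated time of 48 h (on this read-out lower numbers stand for stronger inhibition and higher numbers for weaker inhibition), compound 1 (`COc1ccc2c(/C=C/C(=O)c3cc(OC)c(OC)c(SC)c3)c[nH]c2c1`) gives 115 nM and compound 2 (`COc1ccc2c(/C=C/C(=O)c3cc(N)c(OC)c(OC)c3)c[nH]c2c1`) gives 193 nM. Compound 2 has the higher number of the pair, but the two values lie within the scatter of each other, so neither can be ranked ahead.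

The next compound is compound 3 (`COc1ccc2c(/C=C/C(=O)c3cc(OC)c(OC)c([Se]C)c3)c[nH]c2c1`), and the change from compound 2 is a group of 2 heavy atoms (1 carbon, 1 selenium; no ring) in place of one nitrogen atom, on an aromatic carbon. The amino group leaves, and a group of carbon and selenium with no ring enters on the same aromatic carbon, ortho to a methoxy group.

For the measured compounds named here, only one measured step bears on this change. In a 1.7-fold higher number from compound 1 to compound 2 (0.22 log units; within the scatter), amino took the place of methylsulfanyl on an aromatic carbon, and the shift stayed within the scatter. Going by the values given here, no measured compound yet carries selenium, so this evidence is thin. In this assay, the expectation is therefore no step beyond the scatter, with a slight lean towards lower numbers. The expected size is a 1.8-fold lower number from compound 2 to compound 3 (0.24 log units; within the scatter). Compound 3 is estimated at 110 nM, with an expected range from 35 nM to 350 nM.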

Compound 3, half-maximal inhibitory concentration: 67 nM
Compound 3: the middle estimate sits 1.6-fold (0.22 log units) above what was measured, and the stated range covers the measured number.
By their numbers in this assay, from the lowest: compounds 3, 1 and 2 (each within the scatter of the next, the first and the last beyond it).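

At this aromatic carbon, this assay now gives a step that clears the scatter: the selenium-bearing group in place of amino gives a 2.9-fold lower number from compound 2 to compound 3 (0.46 log units; beyond the scatter). The earlier pair, methylsulfanyl against amino, stayed within the scatter, so until now this position had not separated any two groups. Exchanging sulfur for selenium gives a 1.7-fold lower number from compound 1 to compound 3 (0.23 log units; within the scatter), so methylsulfanyl and the selenium-bearing group cannot be ranked, and the only gap beyond the scatter among these compounds is the one between amino and the selenium-bearing group.

Nothing available here explains why amino and the selenium-bearing group differ in this way.

A methoxy group on this carbon, a dimethylamino group, or an ethyl chain on the selenium in place of its single carbon would help show whether the gap from amino depends on selenium itself or also appears with other groups. These three compounds also leave open whether the same gap between amino and the selenium-bearing group would appear in cells other than the single line tested here.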